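The source may hold more compounds than are shown below. What is called first, only, known or untested is meant among the compounds shown, and "the series" means these compounds.

Working notes on the series, read in an ADME assay on NHDF cells (Homo sapiens) for cytotoxicity, read by MTT assay, with a stated time of 72 h; a lower number here means a stronger inhibitor, a higher number a weaker inhibitor. Compound 1 `COc1cccc(/C=C2\CCC/C(=C\c3cccc(Cl)c3)C2=O)c1OC` gives 21400 nM, compound 2 `COc1cccc(/C=C2\CCC/C(=C\c3ccc(Cl)cc3)C2=O)c1OC` gives 18600 nM and compound 3 `COc1cccc(/C=C2\CCC/C(=C\c3cccc(OC)c3OC)C2=O)c1` gives 16400 nM. These three values lie within the scatter of one another, so compound 3 stands level with the other two.

The next structure is compound 4 `COc1cccc(/C=C2\CCC/C(=C\c3ccc(Cl)cc3Cl)C2=O)c1OC`, with this change from compound 3: 2,4-dichlorophenyl in place of 3-methoxyphenyl on a double-bonded chain carbon bound to a double-bonded ring carbon. In short, 2,4-dichlorophenyl stands in place of 3-methoxyphenyl on a double-bonded chain carbon bound to a double-bonded ring carbon.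

Among the compounds with values here, three measured steps bear on this. With 4-chlorophenyl in place of 3-chlorophenyl the record shows a 1.2-fold lower number from compound 1 to compound 2 (0.06 log units; within the scatter). With methoxy in place of chloro on an aromatic carbon it shows a 1.3-fold lower number from compound 1 to compound 3 (0.12 log units; within the scatter). With 3-methoxyphenyl in place of 4-chlorophenyl it shows a 1.1-fold lower number from compound 2 to compound 3 (0.05 log units; within the scatter). Within the data shown here, all three are within the scatter, though no measured compound carries 2,4-dichlorophenyl. No step beyond the scatter is therefore expected in this assay, and no direction is favoured.

The estimated step is a 1.0-fold higher number from compound 3 to compound 4 (0.02 log units; within the scatter). For compound 4 the expected value is 17000 nM, with an estimated range of 9000 nM to 32000 nM.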

Compound 4, half-maximal inhibitory concentration: 49200 nM
Beside the measured number, compound 4's estimate is 2.9-fold (0.46 log units) below it; the whole stated range lies below it.
By their numbers in this assay, from the lowest: compounds 3, 2 and 1 (each within the scatter of the next); then compound 4.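

Within the data shown here, at the place on a double-bonded chain carbon bound to a double-bonded ring carbon, the earlier exchanges in this assay all stayed within the scatter, and 2,4-dichlorophenyl is the first group here to separate from the others, with a 3.0-fold higher number from compound 3 to compound 4 (0.48 log units; beyond the scatter) and with a 2.3-fold higher number from compound 1 to compound 4 (0.36 log units; beyond the scatter) as well. Among these compounds, the cleanest reading is the single change of chloro in place of hydrogen on an aromatic carbon, which gives a 2.6-fold higher number from compound 2 to compound 4 (0.42 log units; beyond the scatter) and shows that this added chloro goes with a higher number, where moving or exchanging one substituent did not. Nothing on record accounts for this rise.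

Open, on these data alone, is whether the rise belongs to the added chloro alone or to the two chloro groups together. Also open, as far as these compounds go, is whether an amine or a carboxylic acid on this ring would stay level with compound 3 or move with compound 4.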